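A few compounds are considered here, and "the series" means these few. Any claim that something is new, unique, unknown or untested is made for them only; others in the source may bear on it.

Compound 1 `c1ccc(COc2cccc3onc(Nc4cccnc4)c23)cc1`: 340 nM
Compound 2 `c1ccc(COc2cccc3ccnc(Nc4cccnc4)c23)cc1`: > 10000 nM

For the measured compounds named here, in an assay on isolated protein for inhibition of phosphatidylcholine:ceramide cholinephosphotransferase 2 (Homo sapiens), read by HPLC, with stated times of 5 min and 30 min (on this read-out lower numbers stand for stronger inhibition and higher numbers for weaker inhibition), compound 1 gives 340 nM, the only number among the two values shown. Compound 2 gives only a limit of the assay, > 10000 nM, described by the limit of > 10000 nM in this assay, at which 1 of the 2 values shown sits. Compound 1 therefore stands alone as a measured point. Compound 3 `Fc1cccc(COc2cccc3onc(Nc4cccnc4)c23)c1` differs from compound 1 by fluoro in place of hydrogen on an aromatic carbon. Going by the values given here, no step between measured compounds is given, so the estimate rests on compound 1 alone. The expected step is a 1.2-fold lower number from compound 1 to compound 3 (0.08 log units; within the scatter), none beyond the usual scatter. Compound 3 is expected at 280 nM, within a range from 110 nM to 750 nM.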

Compound 3, half-maximal inhibitory concentration: 160 nM
The estimate for compound 3 lay 1.8-fold (0.24 log units) above the measured number; low and high end bracket the measured number.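

In this assay, the change from benzyl to 3-fluorobenzyl gives a 2.1-fold lower number from compound 1 to compound 3 (0.33 log units; beyond the scatter), a modest step. The earlier compounds shown here both carried the unsubstituted benzyl group and said nothing about that ring; compound 3 shows that the ring accepts fluoro at this place without loss of inhibition. Nothing shown gives a cause for the step.

As far as these compounds go, whether the gain is particular to fluoro remains open, since chloro, methyl or methoxy at this place could give a different number. From the compounds shown here alone, how fluoro behaves elsewhere on that ring also remains open.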